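Benzyl in place of acetyl: an unmeasured step

The source may report more compounds than this note shows. Statements on the series, on what has been measured and on what is new or still open speak of the compounds shown alone.

In a functional assay on HL-60 cells (Homo sapiens) for cytotoxicity, read by MTT assay, with a stated time of 24 h (on this read-out higher numbers stand for weaker inhibition and lower numbers for stronger inhibition), compound 1 (`CC(=O)Oc1c(Br)cc(Br)cc1Oc1ccc(Br)cc1Br`) gives 29.9 ug/mL. Compound 2 (`COc1ccccc1N1CCN(CCCCCOc2c(Br)cc(Br)cc2Oc2ccc(Br)cc2Br)CC1`) gives 32.2 ug/mL. Among the measured compounds shown here, the two numbers lie within the scatter of each other, so compound 1 stands level with the only other measured compound. For the measured compounds named here, no measured pair differs in just one place, which leaves no direct step to guide a prediction.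

Compound 3 (`Brc1ccc(Oc2cc(Br)cc(Br)c2OCc2ccccc2)c(Br)c1`) has not yet been measured. It differs from compound 1 by a single change, benzyl in place of acetyl on an oxygen on an aromatic ring. The one available hint comes from compound 2, which also carries a group other than acetyl on that oxygen and still reads 32.2 ug/mL. On that thin evidence, no step beyond the scatter is expected in this assay, in either direction. The expected size of the change is an estimate, a 1.1-fold lower number from compound 1 to compound 3 (0.03 log units; within the scatter), and it could prove wrong with so little data. For compound 3 the estimated value is 28 ug/mL, with an expected range from 12 ug/mL to 60 ug/mL.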

Compound 3, half-maximal inhibitory concentration: 27.9 ug/mL
Estimate against measurement, compound 3: 1.0-fold (0.00 log units) above, and the stated range covers the measured number.
By their numbers in this assay, from the lowest: compounds 3, 1 and 2 (each within the scatter of the next).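

In this assay, among the compounds shown here, the result gives the first direct step at this position, on an oxygen on an aromatic ring, and it reads a 1.1-fold lower number from compound 1 to compound 3 (0.03 log units; within the scatter) as the exchange of acetyl for benzyl. Compound 1 and compound 3 therefore stand level, even though 3 heavy atoms with a double bond and a hydrogen-bond acceptor leave and 7 carbon heavy atoms forming a six-membered aromatic ring enter. Compound 2 had offered only an indirect hint, since it is not one change away from compound 1, whereas this pair tests the change itself. Nothing available explains why the exchange leaves these two compounds level.

The compounds shown leave open whether this tolerance extends to a small methyl group, a free hydroxyl on the ring, or a benzyl group bearing a carboxylic acid or an amine. They also leave open whether the same exchange would stay within the scatter if the bromines on the shared core were replaced by chlorine or hydrogen, since every compound here carries the same core.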